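This account rests on a few compounds, and the source may have more. Where it says the series, first, only, none or still open, it means among the compounds named here.

Working notes on the series in an ADME assay on J774.A1 cells (Mus musculus) for cytotoxicity, read by MTT assay, with a stated time of 48 h; on this read-out higher numbers stand for lower toxicity in this test and lower numbers for higher toxicity in this test. Compound 1 `O=C(NCc1ccccc1)c1c([N+](=O)[O-])noc1-c1ccc(Cl)cc1Cl` carries "not determined" (no result reported). Compound 2 `O=C(NCc1ccc(F)cc1)c1c([N+](=O)[O-])noc1-c1ccc(Cl)cc1Cl` gives 86400 nM. Among the compounds with values here, compound 3 `COc1ccc(CNC(=O)c2c([N+](=O)[O-])noc2-c2ccc(Cl)cc2Cl)cc1` gives 80500 nM, level with compound 2 within the scatter, and these are the only numbers so far. Next is compound 4 `COc1cccc(CNC(=O)c2c([N+](=O)[O-])noc2-c2ccc(Cl)cc2Cl)c1`, where 3-methoxyphenyl stands in place of 4-methoxyphenyl on a saturated chain carbon bound to an amide-type nitrogen: 3-methoxyphenyl in place of 4-methoxyphenyl on a saturated chain carbon bound to an amide-type nitrogen. Within the data shown here, the only measured step is a 1.1-fold lower number from compound 2 to compound 3 (0.03 log units; within the scatter), within the scatter, and it exchanges a group rather than moving one, so it bears on this change only loosely. No step beyond the scatter is expected in this assay, in either direction. The expected step is a 1.0-fold lower number from compound 3 to compound 4 (0.00 log units; within the scatter). Compound 4 is estimated at 80000 nM, with an expected range of 45000 nM to 135000 nM.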

Compound 4, half-maximal cytotoxic concentration: 61200 nM
Compound 4: the middle estimate sits 1.3-fold (0.12 log units) above what was measured; the measured number falls inside the stated range.
By their numbers in this assay, from the lowest: compounds 4, 3 and 2 (each within the scatter of the next).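

In this assay, 3-methoxyphenyl in place of 4-methoxyphenyl on a saturated chain carbon bound to an amide-type nitrogen gives a 1.3-fold lower number from compound 3 to compound 4 (0.12 log units; within the scatter) and so stays within the scatter. Within the data shown here, this is the first reading of the same group at a different ring position, as the earlier pair only exchanged one group for another. Set against 4-fluorophenyl, 3-methoxyphenyl gives a 1.4-fold lower number from compound 2 to compound 4 (0.15 log units; within the scatter) and likewise stays within the scatter.

From the compounds shown here alone, whether an amine or a carboxylic acid on the aromatic ring, or a longer chain in place of this one, would hold the number in the same range stays open. Nothing measured here offers an explanation for these readings.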